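Swapping 4-fluorophenyl for 2,4-dimethylphenyl in compound 3

The compounds below may be only part of what the source reports. "The series", "measured", "known", "first", "only" and "open" are said of these compounds alone.

Measured so far in a functional assay on A549 cells (Homo sapiens) for antiproliferative activity, read by MTT assay, with a stated time of 48 h; a higher number here means a weaker inhibitor, a lower number a stronger inhibitor:
- compound 1 `COc1ccc(/C=C/c2cc(OC)cc(OC)c2/C=C/C(=O)c2cccc(Br)c2)cc1`: 8.1 ug/mL
- compound 2 `COc1ccc(/C=C/c2cc(OC)cc(OC)c2/C=C/C(=O)c2ccc(F)cc2)cc1`: 6.6 ug/mL

For the measured compounds named here, compound 2 stands within the scatter of compound 1, its only measured neighbour. Compound 3 `COc1ccc(/C=C/c2cc(OC)cc(OC)c2/C=C/C(=O)c2ccc(C)cc2C)cc1` changes the group on the same carbonyl carbon: 2,4-dimethylphenyl in place of 4-fluorophenyl on a carbonyl carbon. Going by the values given here, the one measured step at that place, a 1.2-fold lower number from compound 1 to compound 2 (0.09 log units; within the scatter), is the only guide, and no compound with methyl groups has been measured. No step beyond the scatter is therefore expected in this assay. The expected step is a 1.1-fold higher number from compound 2 to compound 3 (0.03 log units; within the scatter). Compound 3 is estimated at 7 ug/mL, with an expected range of 3.5 ug/mL to 14 ug/mL.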

Compound 3, half-maximal inhibitory concentration: 0.3 ug/mL
Compound 3: middle estimate off by 23-fold (1.37 log units), on the high side; measured number below the stated range.
By their numbers in this assay, from the lowest: compound 3; then compounds 2 and 1 (each within the scatter of the next).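

In this assay the group on the carbonyl carbon proves far from indifferent: 2,4-dimethylphenyl gives a 22-fold lower number from compound 2 to compound 3 (1.34 log units; beyond the scatter) and a 27-fold lower number from compound 1 to compound 3 (1.43 log units; beyond the scatter) in the same comparison. For the compounds shown here, the earlier exchange of 3-bromophenyl for 4-fluorophenyl stayed within the scatter, so only this change shows how strongly the position can respond. Nothing measured here explains why the 2,4-dimethylphenyl group does so much better.

From the compounds shown here alone, whether a single methyl group would be enough remains open. So does whether an amine or a longer alkyl chain on that ring would give a similar result.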